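A few compounds are considered here, and "the series" means these few. Any claim that something is new, unique, unknown or untested is made for them only; others in the source may bear on it.

Compound 1 `COc1cccc(/C=C/C(=O)c2c(OC)cc(OC)cc2OC)c1`: 3100 nM
Compound 2 `COc1cc(OC)c(C(=O)/C=C/c2ccccc2)c(OC)c1`: 5100 nM
Compound 3 `COc1cc(O)c(C(=O)/C=C/c2ccccc2OC)c(OC)c1`: 9600 nM

These values come from a functional assay on PC-3 cells (Homo sapiens) for cytotoxicity, with a stated time of 48 h; a higher number here means a weaker inhibitor, a lower number a stronger inhibitor. With 5100 nM, compound 2 holds the middle number of the three, and it lies within the usual scatter of both compound 1 and compound 3. Compound 4 `COc1cc(OC)c(C(=O)/C=C/c2ccc(Br)cc2)c(OC)c1` differs from compound 2 by bromo in place of hydrogen on an aromatic carbon, para to a large group: bromo in place of hydrogen on an aromatic carbon. Among the compounds with values here, no measured compound carries bromo. Within the data shown here, the one measured step on a single group is a 1.6-fold higher number from compound 1 to compound 2 (0.22 log units; within the scatter), where hydrogen replaces methoxy on an aromatic carbon. That small step gives only weak guidance, so no shift beyond the scatter, in either direction, is expected in this assay. The expected step is a 1.2-fold lower number from compound 2 to compound 4 (0.08 log units; within the scatter). Compound 4 is estimated at 4200 nM, with an expected range from 1700 nM to 10500 nM.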

Compound 4, half-maximal inhibitory concentration: 7100 nM
Compound 4: middle estimate off by 1.7-fold (0.23 log units), on the low side, and the stated range covers the measured number.
By their numbers in this assay, from the lowest: compounds 1, 2, 4 and 3 (each within the scatter of the next, the first and the last beyond it).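

In this assay, bromo in place of hydrogen on an aromatic carbon, para to a large group, leaves the number within the scatter (a 1.4-fold higher number from compound 2 to compound 4 (0.14 log units; within the scatter)), so a bromine atom at this position brings no clear change. The wider swap of 3-methoxyphenyl for 4-bromophenyl does go beyond the scatter, though only modestly (a 2.3-fold higher number from compound 1 to compound 4 (0.36 log units; beyond the scatter)). The compounds shown offer no measurement that explains either step. As far as these compounds go, whether an amine or a carboxylic acid at this same position would shift the number further remains open.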